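Working notes: aryl swap at the pyridine carbon, clearance outlook

The source may hold more compounds than are shown below. What is called first, only, known or untested is meant among the compounds shown, and "the series" means these compounds.

Measured so far:
compound 1 `Nc1ccc(S(=O)(=O)N2CCN(c3ncc(C(O)(C(F)(F)F)C(F)(F)F)cc3C3CC3)CC2)cn1` — 38 mL.min-1.g-1
compound 2 `Cc1csc(-c2cc(C(O)(C(F)(F)F)C(F)(F)F)cnc2N2CCN(S(=O)(=O)c3ccc(N)nc3)CC2)c1` — 29 mL.min-1.g-1
compound 3 `Nc1ccc(S(=O)(=O)N2CCN(c3ncc(C(O)(C(F)(F)F)C(F)(F)F)cc3-c3ccccc3O)CC2)cn1` — 22 mL.min-1.g-1

In an ADME assay (liver) for metabolic stability, with Liver microsome (Homo sapiens) as the target, using microsomes and NADPH, with a stated time of 30 min, tested at 1 uM (a lower number here means slower removal, a higher number faster removal of the compound), compound 3 gives 22 mL.min-1.g-1, the lowest of the three numbers, but its steps to the others, a 1.3-fold lower number from compound 2 to compound 3 (0.12 log units; within the scatter) and a 1.7-fold lower number from compound 1 to compound 3 (0.24 log units; within the scatter), are both within the scatter, so no ordering among compounds 1, 2 and 3 can be claimed.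

Compound 4 `Nc1ccc(S(=O)(=O)N2CCN(c3ncc(C(O)(C(F)(F)F)C(F)(F)F)cc3-c3ccc4sccc4c3)CC2)cn1` is not yet measured. It differs from compound 3 in one place: 1-benzothiophen-5-yl in place of 2-hydroxyphenyl on an aromatic carbon

The step that bears on this change most directly is a 1.3-fold lower number from compound 2 to compound 3 (0.12 log units; within the scatter), an exchange of one aromatic group for another on the same carbon, which stayed within the scatter; a 1.3-fold lower number from compound 1 to compound 2 (0.12 log units; within the scatter) and a 1.7-fold lower number from compound 1 to compound 3 (0.24 log units; within the scatter) likewise stayed within the scatter. On that basis no step beyond the scatter is expected from compound 3 to compound 4 in this assay; the expected step is a 1.4-fold higher number from compound 3 to compound 4 (0.13 log units; within the scatter).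

Compound 4 is accordingly estimated at 30 mL.min-1.g-1, with a range from 15 mL.min-1.g-1 to 60 mL.min-1.g-1.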

Compound 4, intrinsic clearance in microsomes: 48 mL.min-1.g-1
The estimate for compound 4 lay 1.6-fold (0.20 log units) below the measured number; the range from low to high includes it.
By their numbers in this assay, from the lowest: compounds 3, 2, 1 and 4 (each within the scatter of the next, the first and the last beyond it).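

In this assay, for the compounds shown here, 1-benzothiophen-5-yl in place of 2-hydroxyphenyl gives a 2.2-fold higher number from compound 3 to compound 4 (0.34 log units; beyond the scatter), the first step at this position to lie beyond the scatter, so the group on this aromatic carbon can shift intrinsic clearance, though only modestly. The other two steps, a 1.7-fold higher number from compound 2 to compound 4 (0.22 log units; within the scatter) and a 1.3-fold higher number from compound 1 to compound 4 (0.10 log units; within the scatter), stay within the scatter, so 1-benzothiophen-5-yl cannot be ordered against 4-methylthiophen-2-yl or cyclopropyl. The series therefore shows one separated pair, not a trend across the four groups.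

The data do not tell whether the loss of the hydroxyl group or the gain of the five-membered aromatic ring carries the step, and no supporting evidence bears on the result. On these data alone, how an aminomethyl group or a carboxylic acid on this aromatic carbon would read also remains open.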